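The source may report more compounds than this note shows. Statements on the series, on what has been measured and on what is new or still open speak of the compounds shown alone.

Compound 1 `Cc1ccc2c(c1)OCC(=O)N2Cc1cn(Cc2ccccc2)nn1`: 54900 nM
Compound 2 `O=C1COc2ccc(F)cc2N1Cc1cn(Cc2ccccc2)nn1`: > 100000 nM (a limit of the assay, not a number)
Compound 3 `CCC1Oc2ccccc2N(Cc2cn(Cc3ccccc3)nn2)C1=O`: > 100000 nM (a limit of the assay, not a number)

For the measured compounds named here, all three compounds were tested in a functional assay on HT-29 cells (Homo sapiens) for cytotoxicity, read by MTT assay, with a stated time of 6 days (on this read-out lower numbers stand for stronger inhibition and higher numbers for weaker inhibition), where compound 1 is the only one with an actual number. Compound 3 stands at > 100000 nM, which is a limit and gives no exact position on the scale. Compound 3 shares this with compound 2, and together they make up (the limit of > 100000 nM in this assay, at which 2 of the 3 values shown sit).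

Compound 4 `CCCC1Oc2ccccc2N(Cc2cn(Cc3ccccc3)nn2)C1=O` differs from compound 3 by a single change, (methyl in place of hydrogen on a saturated chain carbon, two bonds along the chain from a saturated ring carbon). In words, this is methyl in place of hydrogen on a saturated chain carbon, two bonds along the chain from a saturated ring carbon, so the ethyl group becomes a propyl group.

Going by the values given here, no two measured compounds here differ in just one place, so the data do not directly show how large such a change might be. In this assay, the expectation is therefore for no step beyond the scatter, and another limit is the likeliest result. This expectation rests on compound 3, with its > 100000 nM, as the closest measured neighbour. The expected change is a number no higher from compound 3 to compound 4 (the limit leaves the size open). For compound 4 the estimated value is 100000 nM, with an expected range of 45000 nM to 220000 nM.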

Compound 4, half-maximal inhibitory concentration: > 100000 nM
Compound 4 ended at the assay's limit; the forecaster's own chance of this, stated with the estimate: 65%; the middle value sits exactly at the limit.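

Compound 3 and compound 4 both ended at a limit of the assay rather than at an actual number, so no step can be read between them: the limit of > 100000 nM in this assay, at which 3 of the 4 values shown sit.

The compounds shown leave open whether going from ethyl to propyl changes the result in this assay at all, and by how much.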